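Sulfonamide linker variation on a shared cytotoxic core

The source may report more compounds than this note shows. Statements on the series, on what has been measured and on what is new or still open speak of the compounds shown alone.

compound 1, `O=S(=O)(NCCCNc1nccc(-c2c(-c3cccc(F)c3)nc3sccn23)n1)c1cccc(F)c1`: 13700 nM
compound 2, `Cc1ccc(S(=O)(=O)NCCCNc2nccc(-c3c(-c4cccc(F)c4)nc4sccn34)n2)cc1`: 8380 nM

In a functional assay on A-375 cells (Homo sapiens) for cytotoxicity, read by MTT assay (on this read-out higher numbers stand for weaker inhibition and lower numbers for stronger inhibition), compound 2 gives 8380 nM, the lowest of the two numbers shown, although the step of a 1.6-fold lower number from compound 1 to compound 2 (0.21 log units; within the scatter) lies within the scatter. Compound 3 `O=S(=O)(NCCNc1nccc(-c2c(-c3cccc(F)c3)nc3sccn23)n1)c1ccccc1` differs from compound 2 by (phenylsulfonyl)amino in place of (((4-methylphenyl)sulfonyl)amino)methyl on a saturated chain carbon, two bonds along the chain from a nitrogen on an aromatic ring. Among the measured compounds shown here, only the step of a 1.6-fold lower number from compound 1 to compound 2 (0.21 log units; within the scatter) bears on the aryl part of this change, and it stayed within the scatter; the change in the chain has no measured counterpart. Compound 3 is therefore expected to sit close to compound 2, with an estimated step of a 1.3-fold higher number from compound 2 to compound 3 (0.12 log units; within the scatter) not expected to exceed the scatter. The estimate for compound 3 in this assay is 11000 nM, expected between 4500 nM and 27000 nM.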

Compound 3, half-maximal inhibitory concentration: 11000 nM
For compound 3 middle estimate and measured number coincide at the digits printed, and the stated range covers the measured number.
By their numbers in this assay, from the lowest: compounds 2, 3 and 1 (each within the scatter of the next).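

In this assay, (phenylsulfonyl)amino in place of (((4-methylphenyl)sulfonyl)amino)methyl gives a 1.3-fold higher number from compound 2 to compound 3 (0.12 log units; within the scatter) and the matching replacement of (((3-fluorophenyl)sulfonyl)amino)methyl gives a 1.2-fold lower number from compound 1 to compound 3 (0.10 log units; within the scatter) so a change reaching the chain, which the earlier step did not touch, also stays within the scatter at this position. No available evidence accounts for this result. As far as these compounds go, the chain and aryl changes occur together here, so their separate contributions remain open, as does what a longer chain or a carboxylic acid on the aryl ring would do.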